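The compounds below may be only part of what the source reports. "The series", "measured", "known", "first", "only" and "open" are said of these compounds alone.

Working notes on the series.

Compound 1 `Cc1cc(C(F)(F)F)cc(NC[C@@H]2CC3(CC3)CN2C(=O)c2nc(C)sc2-c2ccccc2)n1` is the reference point. In a functional assay on HEK293 cells for antagonist activity at Orexin receptor type 2 (Homo sapiens), read by FLIPR and calcium flux (on this read-out lower numbers stand for lower potency and higher numbers for higher potency (the scale is a negative logarithm)), compound 1 gives 8.6, the highest of the three numbers in hand and beyond the scatter from both others. Compound 2 `O=C(c1nc(C(F)(F)F)ccc1-c1ncccn1)N1CC2(CC2)C[C@H]1CNc1ccc(C(F)(F)F)cn1` gives 5 in this assay, and compound 3 `O=C(c1ncccc1-c1ncccn1)N1CC2(CC2)C[C@H]1CNc1ccc(C(F)(F)F)cn1` gives 5; both sit far below compound 1. Among the measured compounds shown here, the one single-point step measured so far, no change at the digits printed from compound 2 to compound 3 (within the scatter), concerns a trifluoromethyl against hydrogen on an aromatic carbon of the core and leaves both compounds at the floor; it says nothing directly about the aryl group on the amine nitrogen, which is the place now in question.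

Compound 4 `Cc1cc(C)nc(NC[C@@H]2CC3(CC3)CN2C(=O)c2nc(C)sc2-c2ccccc2)n1` differs from compound 1 by 4,6-dimethylpyrimidin-2-yl in place of 6-methyl-4-(trifluoromethyl)pyridin-2-yl on an amine nitrogen. For the measured compounds named here, no measured pair isolates a change at this amine nitrogen, so the expectation rests on compound 1 alone, which carries the same core as compound 4 and stands high. With two ring nitrogens and two methyls entering where one ring nitrogen, one methyl and a trifluoromethyl leave, a modest step downward from compound 1 to compound 4 is expected, a number 0.60 log units lower from compound 1 to compound 4 (beyond the scatter), nothing near the drop seen for compound 2 and compound 3. Compound 4 is therefore estimated at 8 in this assay, with a range from 7.2 to 8.7.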

Compound 4, negative logarithm of the antagonist equilibrium constant: 8.6
Compound 4: middle estimate off by 0.60 log units, on the low side; low and high end bracket the measured number.
By their numbers in this assay, from the lowest: compounds 2 and 3 (each within the scatter of the next); then compounds 1 and 4 (each within the scatter of the next).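

Among the compounds shown here, the pair gives no change at the digits printed from compound 1 to compound 4 (within the scatter), the first measured step at the aryl group on the amine nitrogen; in this assay the core of compound 1 therefore keeps its high reading when 4,6-dimethylpyrimidin-2-yl replaces 6-methyl-4-(trifluoromethyl)pyridin-2-yl. On this core, then, a high reading needs neither the trifluoromethyl group nor the pyridine form of the ring, at least in this one exchange of aromatic groups. No measurement on hand bears on the reason the two groups read alike.

Open, going by these compounds, is how much further the aryl group on this amine nitrogen can vary on the same core: a plain phenyl ring, a pyrimidin-2-yl ring without its methyl groups, or a ring carrying a methoxy group or a nitrile would each test the limits of this result. On these data alone, compound 2 and compound 3 differ from compound 1 in more than one place, so their low readings cannot yet be assigned to any single part of those structures, and whether 4,6-dimethylpyrimidin-2-yl would behave the same way on their core remains unknown.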